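Replacing benzoyl with a methyl ester chain on the amine

A few compounds are considered here, and "the series" means these few. Any claim that something is new, unique, unknown or untested is made for them only; others in the source may bear on it.

Within the data shown here, compound 2 `Cc1cn([C@@H]2O[C@H](CO[Si](C)(C)C(C)(C)C)[C@@]3(OS(=O)(=O)C=C3NC(=O)c3ccccc3)[C@H]2O[Si](C)(C)C(C)(C)C)c(=O)n(C)c1=O` gives 4900 nM in a functional assay on MT4 cells (Homo sapiens) (on this read-out lower numbers stand for higher toxicity in this test and higher numbers for lower toxicity in this test), and is the only compound here with a plain number rather than a limit. Compound 1 `Cc1cn([C@@H]2O[C@H](CO[Si](C)(C)C(C)(C)C)[C@@]3(OS(=O)(=O)C=C3NCCC(=O)OCc3ccccc3)[C@H]2O[Si](C)(C)C(C)(C)C)c(=O)n(C)c1=O` reaches only a limit of the test, > 250000 nM. Among the measured compounds shown here, the single measured step, an at least 51-fold lower number from compound 1 to compound 2 (1.70 log units; beyond the scatter), thus rests on the limit (the limit of > 250000 nM in this assay, at which 1 of the 2 values shown sits), so its true size is unknown beyond being large. Compound 3 `COC(=O)CCNC1=CS(=O)(=O)O[C@@]12[C@@H](CO[Si](C)(C)C(C)(C)C)O[C@@H](n1cc(C)c(=O)n(C)c1=O)[C@@H]2O[Si](C)(C)C(C)(C)C` differs from compound 2 by 2-(methoxycarbonyl)ethyl in place of benzoyl on an amine nitrogen. This change runs in the opposite sense to the measured step: an ester-bearing chain again takes the place of the benzoyl on the amine nitrogen, much as in compound 1. Compound 3 is therefore expected to show a 24-fold higher number from compound 2 to compound 3 (1.39 log units; beyond the scatter), a large rise. The estimate for compound 3 is 120000 nM, with a range from 25000 nM to 300000 nM, and a real chance that this assay again reports only a limit.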

Compound 3, half-maximal cytotoxic concentration: > 250000 nM
Compound 3: no number, only a limit; the forecaster's own chance of this, stated with the estimate: 45%; at least 2.0-fold (0.31 log units) between middle value and limit.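

In this assay compound 3 gives > 250000 nM, which is a limit of the test and not a number. With 2-(methoxycarbonyl)ethyl in place of benzoyl on the amine nitrogen, the result is an at least 51-fold higher number from compound 2 to compound 3 (1.70 log units; beyond the scatter), so a second ester-bearing chain behaves like the benzyl ester chain of compound 1, and the lower number stays with the benzoyl compound alone. The step between compound 1 and compound 3 cannot be read, and the true size of the rise from benzoyl stays unknown for this reason: the limit of > 250000 nM in this assay, at which 2 of the 3 values shown sit.

Going by these compounds, what stays open is which part of benzoyl goes with the lower number of compound 2, its ring or its carbonyl. An acetyl or a benzyl group on the same amine nitrogen would tell these two apart.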